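A few compounds are considered here, and "the series" means these few. Any claim that something is new, unique, unknown or untested is made for them only; others in the source may bear on it.

Working notes on the series. Among the compounds with values here, compound 1 `Cc1nc(-c2cc3cc(NCc4ccccc4)cc(C#N)c3[nH]2)sc1C(=O)O` gives "not determined" (no result reported) in a functional assay on the whole organism (plasma, strain Sprague-Dawley) for inhibition, with Rattus norvegicus as the target, with a stated time of 1 h, at a dose of 10 mg/kg by the oral route (a lower number here means less inhibition, a higher number more inhibition at the dose given (going by the name of the read-out)), that is, no result; the single number in this assay belongs to compound 2. Compound 2 `COc1cc([N+](=O)[O-])c2[nH]c(-c3nc(C)c(C(=O)O)s3)cc2c1` gives 4% in this assay, which stands alone, with nothing else to compare it against, and points to little inhibition at the dose given. Compound 3 `Cc1nc(-c2cc3cc(CNS(C)(=O)=O)cc([N+](=O)[O-])c3[nH]2)sc1C(=O)O` carries one change against compound 2: (methanesulfonamido)methyl in place of methoxy on an aromatic carbon. Within the data shown here, no measured pair shows such an exchange, so its effect in this assay is unknown. With compound 2 at 4% there is little room for a downward step, and nothing in the data supports a large upward one; the step of a number 4 percentage points higher from compound 2 to compound 3 (within the scatter) is expected to stay within the usual scatter. Compound 3 is therefore estimated at 8% in this assay, with a range from 0% to 25%.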

Compound 3, a percentage reported as inhibition, in the whole organism at one dose (the size of the read-out at that dose, not a potency): 0%
For compound 3 the middle estimate is 8 percentage points above the measured one, within the range that was stated.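

In this assay, within the data shown here, (methanesulfonamido)methyl in place of methoxy on this aromatic carbon, meta to the nitro group, gives a number 4 percentage points lower from compound 2 to compound 3 (within the scatter), the first step that can be read. The larger group, with its hydrogen-bond donor, therefore brings no inhibition at the dose given beyond that of methoxy, and both compounds stay at the low end of the read-out, where a further drop would be hard to see. Nothing at hand bears on the reason for this result.

On these data alone, whether an amine or a carboxylic acid on this aromatic carbon would raise the read-out above the level of compound 2 and compound 3 stays open. Also open, as far as these compounds go, is whether any exchange here can show an effect while the nitro group remains in place.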